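This account rests on a few compounds, and the source may have more. Where it says the series, first, only, none or still open, it means among the compounds named here.

Working notes on a short series of cinnamic-acid type compounds tested in a functional assay on the whole organism (strain CD1) for inhibition, with Mus musculus as the target, with stated times of 15 min and 20 min, at a dose of 10 mg/kg by the subcutaneous route; on this read-out lower numbers stand for less inhibition and higher numbers for more inhibition at the one dose given (going by the name of the read-out).

Compound 1 `O=C(O)/C(F)=C/c1ccc(O)c(O)c1` carries a fluoro on the chain and a catechol-bearing ring; in this assay compound 1 gives -5.8%. Compound 2 `CC(C)(C)OC(=O)/C(C#N)=C/c1ccc(O)c(O)c1` carries a nitrile on the chain and a tert-butyl ester; in this assay compound 2 gives 43.4%. Compound 3 `NC/C(=C\c1ccccc1)C(=O)O` carries an aminomethyl on the chain and an unsubstituted ring; in this assay compound 3 gives -2.4%.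

Compound 3 stands second highest of the three numbers. Its nearest neighbour is compound 1, lower by an amount within the scatter, so the two cannot be told apart. Compound 2 stands well beyond the scatter above it.

Compound 4 `O=C(O)/C(F)=C/c1ccccc1` is the unmeasured member. Compound 4 differs from compound 3 by fluoro in place of aminomethyl on a double-bonded chain carbon bound to a carbonyl carbon and a double-bonded chain carbon. Within the data shown here, no measured step covers this change. Compound 1, which also carries the fluoro on the chain, gives -5.8%, a number within the scatter of compound 3, so no step beyond the scatter is expected in this assay. The expected step from compound 3 to compound 4 is a number 2.4 percentage points higher from compound 3 to compound 4 (within the scatter). Compound 4 is estimated at 0%, with a range from -15% to 15%.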

Compound 4, a percentage reported as inhibition, in the whole organism at one dose (the size of the read-out at that dose, not a potency): 34%
Compound 4: the middle estimate sits 34 percentage points below what was measured; measured number outside the range, above it.
By their numbers in this assay, from the lowest: compounds 1 and 3 (each within the scatter of the next); then compounds 4 and 2 (each within the scatter of the next).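

In this assay, the read-out proves sensitive to the group on the double-bonded chain carbon bound to a carbonyl carbon and a double-bonded chain carbon: fluoro in place of aminomethyl brings a number 36.4 percentage points higher from compound 3 to compound 4 (beyond the scatter), the only single-place change shown in the series. Fluoro at this position does not settle the read-out alone, since compound 1 also carries it and gives -5.8%, but that compound differs from compound 4 in more than one place, so no step can be read. Nothing at hand accounts for the size of the step.

As far as these compounds go, it remains open whether a chloro or a methyl at this chain carbon would behave as fluoro does. Also open, from the compounds shown here alone, is how a single hydroxyl on the otherwise unsubstituted ring would change the number for compound 4.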